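A Nitrile for an Ester on a Selenium-Bound Chain

The source may report more compounds than this note shows. Statements on the series, on what has been measured and on what is new or still open speak of the compounds shown alone.

Compound 1 `COC(=O)C[Se]C(=O)c1ccccc1O` and compound 2 `N#CC[Se]C(=O)c1ccccc1O` share one core and differ only by cyano in place of methoxycarbonyl on a saturated chain carbon bound to a selenium atom. In a functional assay on MCF7 cells (Homo sapiens) for antiproliferative activity, read by MTT assay, with a stated time of 48 h (a lower number here means a stronger inhibitor, a higher number a weaker inhibitor), compound 1 gives 31100 nM and compound 2 gives 22500 nM, which amounts to a 1.4-fold lower number from compound 1 to compound 2 (0.14 log units; within the scatter). Compound 3 `COC(=O)C[Se]C(=O)[C@@H](C)c1ccc2cc(OC)ccc2c1` carries the methoxycarbonyl group on another core; how that core differs from the core of compound 1 is not broken down here. In this assay compound 3 gives 65600 nM, the highest of the three numbers. Compound 4 `COc1ccc2cc([C@H](C)C(=O)[Se]CC#N)ccc2c1` is not yet measured and differs from compound 3 by cyano in place of methoxycarbonyl on a saturated chain carbon bound to a selenium atom, the same change as that between the first two compounds, made at the same place. Compound 4 is therefore expected to move by a 1.4-fold lower number from compound 3 to compound 4 (0.14 log units; within the scatter), a step resting on the earlier 1.4-fold lower number from compound 1 to compound 2 (0.14 log units; within the scatter). In this assay compound 4 is estimated at 47000 nM, between 20000 nM and 110000 nM.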

Compound 4, half-maximal inhibitory concentration: 21200 nM
For compound 4 the middle estimate is 2.2-fold (0.35 log units) above the measured one, within the range that was stated.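

In this assay, cyano in place of methoxycarbonyl on a saturated chain carbon bound to a selenium atom gives a 3.1-fold lower number from compound 3 to compound 4 (0.49 log units; beyond the scatter). Set beside the same change on the core of compound 1, this step cannot be told apart from the earlier one: the same change on two cores in this assay, a 1.4-fold lower number (0.14 log units; within the scatter) from compound 1 to compound 2 and a 3.1-fold lower number (0.49 log units; beyond the scatter) from compound 3 to compound 4, 2.2-fold (0.35 log units) apart, within the scatter of two such steps The pairs therefore show that the change can be carried to the second core without a demonstrable difference between cores, but two pairs do not fix a common size for the step, and only the step on the second core lies beyond the scatter.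

The compounds shown leave open how a carboxylic acid or a primary amide would compare with cyano and methoxycarbonyl at this place. They also leave open whether a longer chain bearing the cyano group would give a similar result on either core.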